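The source may hold more compounds than are shown below. What is called first, only, known or untested is meant among the compounds shown, and "the series" means these compounds.

Going by the values given here, compound 2 `COc1cc(C)cc(-c2nn(CC#N)cc2-c2ccnc(-c3ccc(N(C)C)cc3)c2)c1` sits at the higher of the two numbers measured so far. In a functional assay on OVCAR-3 cells (Homo sapiens) for cytotoxicity, read by sulforhodamine B assay, with a stated time of 48 h, tested at 1 uM (on this read-out lower numbers stand for a stronger effect and higher numbers for a weaker effect at the one concentration tested), compound 2 gives -41%. Its nearest neighbour, compound 1 `Cc1cc(O)cc(-c2nn(CC#N)cc2-c2ccnc(-c3ccc(Oc4ccccc4)cc3)c2)c1`, differs from it in more than one place, and in this assay compound 1 gives -63%, a number lying beyond the usual scatter below that of compound 2. Compound 3 `Cc1cc(O)cc(-c2nn(CC#N)cc2-c2ccnc(-c3ccc(N(C)C)cc3)c2)c1` has not yet been measured. It differs from compound 2 in one place: hydrogen in place of methyl on an oxygen on an aromatic ring Read one bond further out, the change is methoxy to hydroxy, so compound 3 carries the 3-hydroxy-5-methylphenyl seen in compound 1. Among the compounds with values here, no single-change step between measured compounds is available to calibrate this. Compound 1, which bears the hydroxy, gives -63%, though its second difference from compound 2 blurs the comparison. A downward step of about a number 11 percentage points lower from compound 2 to compound 3 (beyond the scatter) is therefore expected. Compound 3 is estimated at -52%, within a range from -75% to -30%.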

Compound 3, a percentage reported as activity, at one concentration (the size of the read-out at that concentration, not a potency): -40%
Beside the measured number, compound 3's estimate is 12 percentage points below it; low and high end bracket the measured number.
By their numbers in this assay, from the lowest: compound 1; then compounds 2 and 3 (each within the scatter of the next).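

In this assay, the methoxy to hydroxy change gives a number 1 percentage points higher from compound 2 to compound 3 (within the scatter), so with dimethylamino in the molecule, hydrogen in place of methyl on this oxygen leaves the read-out within the scatter. The single-change step that now carries the difference lies at the other place, where dimethylamino in place of phenoxy on an aromatic carbon gives a number 23 percentage points higher from compound 1 to compound 3 (beyond the scatter), a step beyond the scatter. Nothing at hand gives a reason for either step.

The compounds shown leave open whether ethyl on this oxygen, or an amine in place of the hydroxy, would keep the read-out where it stands. They also leave open whether methoxy to hydroxy would give a similar step with phenoxy on the other ring, and how a cyclic amine such as morpholine would compare with dimethylamino.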